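Working notes: furan-3-yl for phenyl on the shared core

The source may report more compounds than this note shows. Statements on the series, on what has been measured and on what is new or still open speak of the compounds shown alone.

Compound 1 `COc1nc(N)nc2c1c(-c1ccccc1)cn2[C@@H]1O[C@H](CO)[C@@H](O)[C@H]1O` sits at a limit of the assay: in a functional assay on HCT-116 cells (Homo sapiens), read by MTT assay, with a stated time of 72 h (a lower number here means a stronger inhibitor, a higher number a weaker inhibitor), compound 1 gives > 20000 nM. Compound 2 `Nc1nc(N)c2c(-c3ccccc3)cn([C@@H]3O[C@H](CO)[C@@H](O)[C@H]3O)c2n1` also gives only a limit in this assay, > 20000 nM. Compound 3 `COc1ncnc2c1c(-c1ccccc1)cn2[C@@H]1O[C@H](CO)[C@@H](O)[C@H]1O` likewise reaches only a limit, > 20000 nM. Accordingly a step that the two limits leave unreadable from compound 1 to compound 2 and a step that the two limits leave unreadable from compound 1 to compound 3 are both unreadable, and the limit of > 20000 nM in this assay, at which 3 of the 3 values shown sit, is all the evidence there is. Compound 4 `COc1nc(N)nc2c1c(-c1ccoc1)cn2[C@@H]1O[C@H](CO)[C@@H](O)[C@H]1O` differs from compound 1 by furan-3-yl in place of phenyl on an aromatic carbon. No measured step bears on this change, and with every shown value at the limit no direction beyond the scatter can be read. Compound 4 is therefore expected to sit at the limit too, with a step that the limit leaves unreadable from compound 1 to compound 4 estimated as no readable step. The estimate for compound 4 is 30000 nM, spanning 8000 nM to 100000 nM.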

Compound 4, half-maximal inhibitory concentration: > 20000 nM
Compound 4: no number, only a limit; the forecaster's own chance of this, stated with the estimate: 85%; the middle value does not contradict the limit.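

In this assay, within the data shown here, compound 4 gives only a limit, > 20000 nM, so no step from compound 1 to compound 4 can be read. The compounds shown leave open whether any change on the shared core gives a measurable value: the limit of > 20000 nM in this assay, at which 4 of the 4 values shown sit.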